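Swapping the ester aryl group in a sulfamoyl carbamate

The compounds below may be only part of what the source reports. "The series", "measured", "known", "first", "only" and "open" are said of these compounds alone.

This small set shares a core built around a sulfamoyl group attached to a carbonyl, and each member is tested in an assay on liver for inhibition of sterol O-acyltransferase 1 (Rattus norvegicus), using microsomes; a higher number here means a weaker inhibitor, a lower number a stronger inhibitor. Compound 1 `CCC(C)N(C(=O)NS(=O)(=O)Oc1c(C(C)C)cccc1C(C)C)C(C)CC` gives 12000 nM in this assay. Compound 2 `CC(C)c1cccc(C(C)C)c1OS(=O)(=O)NC(=O)Sc1c(C(C)C)cccc1C(C)C` gives 8700 nM in this assay. Compound 3 `CC(C)c1cccc(C(C)C)c1OS(=O)(=O)NC(=O)Oc1cccnc1` reaches only a limit of this assay, > 50000 nM, so its true number is not known (the limit of > 50000 nM in this assay, at which 1 of the 3 values shown sits). Compound 3 therefore stands as the weakest of the measured three, and the step of an at least 4.1-fold higher number from compound 1 to compound 3 (0.61 log units; beyond the scatter) shows how far it falls behind compound 1.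

Compound 4 `CC(C)c1ccccc1OC(=O)NS(=O)(=O)Oc1c(C(C)C)cccc1C(C)C` is compound 3 with one change: 2-isopropylphenyl in place of pyridin-3-yl on an oxygen next to a carbonyl group. Going by the values given here, the only measured step touching compound 3 is the one from compound 1, which moved in the unfavourable direction; the new aryl group in compound 4 resembles the isopropyl-bearing aryl groups in compound 2, whose value 8700 nM lies in the measurable range. In this assay compound 4 is therefore expected to return to a measurable number, an improving step of an at least 3.3-fold lower number from compound 3 to compound 4 (0.52 log units; beyond the scatter). The estimate for compound 4 is 15000 nM, with a range from 4000 nM to 50000 nM.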

Compound 4, half-maximal inhibitory concentration: > 50000 nM
Compound 4 ended at the assay's limit; the forecaster's own chance of this, stated with the estimate: 25%; middle value at least 3.3-fold (0.52 log units) from the limit.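

Compound 3 and compound 4 both sit at a limit of this assay, so the step between them cannot be read: the limit of > 50000 nM in this assay, at which 2 of the 4 values shown sit.

The compounds shown leave open how far the true numbers of compound 3 and compound 4 lie past that limit, and which of the two is the stronger inhibitor.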